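The compounds below may be only part of what the source reports. "The series", "measured", "known", "first", "only" and "open" are said of these compounds alone.

Compound 1 `C=C(C)c1cn(-c2cccc(C(=O)/C=C/c3ccc(O)c(OC)c3)c2)nn1` and compound 2 `COc1cc(/C=C/C(=O)c2cccc(-n3cc(-c4ccccc4C(F)(F)F)nn3)c2)ccc1O` share one core and differ in a single side group. In a functional assay on RAW264.7 cells (Mus musculus) for inhibition, with a stated time of 4 days (on this read-out lower numbers stand for stronger inhibition and higher numbers for weaker inhibition), compound 1 gives 9790 nM, and compound 2 gives 5070 nM; the step of a 1.9-fold lower number from compound 1 to compound 2 (0.29 log units; within the scatter) stays within the scatter, so on the numbers shown compound 2 stands at the lower end with compound 1 as its only neighbour, at a gap within the scatter. Compound 3 `COc1cc(/C=C/C(=O)c2cccc(-n3cc(-c4cccc(Cl)c4)nn3)c2)ccc1O` is the next step: 3-chlorophenyl in place of 2-(trifluoromethyl)phenyl on an aromatic carbon. Within the data shown here, no measured step swaps one aryl group for another on this carbon, and the only step in hand is within the scatter, so the expected change is a 1.1-fold lower number from compound 2 to compound 3 (0.05 log units; within the scatter), nothing beyond the scatter. Compound 3 is thus expected to give 4500 nM, between 1500 nM and 14000 nM.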

Compound 3, half-maximal inhibitory concentration: 14300 nM
Compound 3: the middle estimate sits 3.2-fold (0.50 log units) below what was measured; measured number outside the range, above it.
By their numbers in this assay, from the lowest: compounds 2, 1 and 3 (each within the scatter of the next, the first and the last beyond it).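

In this assay this aromatic carbon gives its first change beyond the scatter (modest in size), so one aryl group cannot simply replace another here (a 2.8-fold higher number from compound 2 to compound 3 (0.45 log units; beyond the scatter)). Set against 1-methylethenyl, the 3-chlorophenyl group stays within the scatter (a 1.5-fold higher number from compound 1 to compound 3 (0.16 log units; within the scatter)). No measurement shown accounts for the shift. The compounds shown leave open whether the substituent on the phenyl ring or its ring position drives this step, since 3-chlorophenyl and 2-(trifluoromethyl)phenyl differ in both. Going by these compounds, how an amine or a carboxylic acid would read on this carbon also remains open.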